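The source may report more compounds than this note shows. Statements on the series, on what has been measured and on what is new or still open speak of the compounds shown alone.

Among the measured compounds shown here, compound 2 `CC1=C/C(=C\c2ccccc2)C(=O)C(C)(O)C12CC2` is the one compound here with a definite number: in a functional assay on MDA-MB-231 cells (Homo sapiens) for antiproliferative activity (a lower number here means a stronger inhibitor, a higher number a weaker inhibitor), compound 2 gives 4000 nM. Compound 1 `CC1=C/C(=C\c2cccs2)C(=O)C(C)(O)C12CC2` reaches only a limit of this assay, > 10000 nM, which is the limit of > 10000 nM in this assay, at which 1 of the 2 values shown sits. For the measured compounds named here, the single measured step, an at least 2.5-fold lower number from compound 1 to compound 2 (0.39 log units; beyond the scatter), concerns a different change. Compound 3 `CC1=C/C(=C\Cl)C(=O)C(C)(O)C12CC2` differs from compound 2 by chloro in place of phenyl on a double-bonded chain carbon bound to a double-bonded ring carbon. Going by the values given here, no measured step trades phenyl for chloro, so the expectation rests on little. A modest weakening is expected, a 2.0-fold higher number from compound 2 to compound 3 (0.30 log units; within the scatter). Compound 3 is estimated at 8000 nM, with a range from 2000 nM to 40000 nM.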

Compound 3, half-maximal inhibitory concentration: 300 nM
Compound 3: middle estimate off by 27-fold (1.43 log units), on the high side; measured number outside the range, below it.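

At this place, on a double-bonded chain carbon bound to a double-bonded ring carbon, activity does not need an aromatic ring: replacing the ring with chloro gives a 13-fold lower number from compound 2 to compound 3 (1.12 log units; beyond the scatter) and an at least 33-fold lower number from compound 1 to compound 3 (1.52 log units; beyond the scatter). Of the compounds shown, compound 3 is therefore the most potent, and the choice of group here matters far more than the swap between the two rings suggested. The value for compound 1 is a limit, not a number: the limit of > 10000 nM in this assay, at which 1 of the 3 values shown sits.

Still open, from the compounds shown here alone, is whether bromo or methyl at this place would match chloro, which would show whether the gain depends on chlorine itself or simply on losing the ring.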